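Swapping the aryl group on a diaryl urea nitrogen

The source may report more compounds than this note shows. Statements on the series, on what has been measured and on what is new or still open speak of the compounds shown alone.

Compound 2 `COc1cc(Cl)cc(-c2nn(-c3cccc(NC(=O)Nc4ccc(Cl)c(Cl)c4)c3)cc2-c2ccncc2)c1` gives 101% in a functional assay on OVCAR-3 cells (Homo sapiens) for inhibition, read by sulforhodamine B assay, with a stated time of 48 h, tested at 0.1 uM (a higher number here means a weaker effect of the compound at the concentration tested, a lower number a stronger effect), the higher of the two values measured, while compound 1 `COc1cc(Cl)cc(-c2nn(-c3cccc(NC(=O)Nc4cc(C(F)(F)F)cc(C(F)(F)F)c4)c3)cc2-c2ccncc2)c1` gives 95%, a gap that lies within the usual scatter. Compound 3 `COc1cc(Cl)cc(-c2nn(-c3cccc(NC(=O)Nc4cccc(C(F)(F)F)c4)c3)cc2-c2ccncc2)c1` has not yet been measured. Among the measured compounds shown here, its only difference from compound 2 is 3-(trifluoromethyl)phenyl in place of 3,4-dichlorophenyl on an amide-type nitrogen. Because compound 1, which also carries trifluoromethyl on that ring, gives 95%, the step of a number 4 percentage points lower from compound 2 to compound 3 (within the scatter) is expected to stay within the scatter, in no particular direction. Compound 3 is therefore estimated to give about 97%, within a range of 85% to 108%.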

Compound 3, a percentage reported as activity, at one concentration (the size of the read-out at that concentration, not a potency): 98%
The estimate for compound 3 lay 1 percentage points below the measured number; the range from low to high includes it.
By their numbers in this assay, from the lowest: compounds 1, 3 and 2 (each within the scatter of the next).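

In this assay putting 3-(trifluoromethyl)phenyl in place of 3,4-dichlorophenyl on the amide-type nitrogen gives a number 3 percentage points lower from compound 2 to compound 3 (within the scatter) and hydrogen in place of trifluoromethyl on an aromatic carbon gives a number 3 percentage points higher from compound 1 to compound 3 (within the scatter) so neither change separates these compounds at this concentration. Both the swap of the whole aryl group and the removal of a single trifluoromethyl leave the read-out unchanged within the scatter. Nothing measured here speaks to why the numbers stay so close. On these data alone, whether an amine or a carboxylic acid on that ring, or a longer alkyl chain in its place, would move the number stays open.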